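Rearranging the Chlorinated Bicyclic Sulfonamide in Compound 2

The source may hold more compounds than are shown below. What is called first, only, known or untested is meant among the compounds shown, and "the series" means these compounds.

Two measured compounds share a core in which an amidine-bearing benzyl group sits on a lactam ring that carries a sulfonamide. Compound 1 `N=C(N)c1cccc(CN2CC[C@H](NS(=O)(=O)c3cc4nc(Cl)ccc4s3)C2=O)c1` has a hydrogen where compound 2 `N=C(N)c1ccc(O)c(CN2CC[C@H](NS(=O)(=O)c3cc4nc(Cl)ccc4s3)C2=O)c1` carries a hydroxy group on an aromatic carbon. In an assay on isolated protein for binding affinity to serine protease 1 (Homo sapiens) (on this read-out lower numbers stand for stronger inhibition and higher numbers for weaker inhibition), compound 1 gives only a limit of the assay, > 2900 nM, not a number. In this assay, among the compounds with values here, compound 2 gives 1600 nM, the only real number among the values shown. From the compounds shown here alone, the change between them amounts to an at least 1.8-fold lower number from compound 1 to compound 2 (0.25 log units; that floor lies within the scatter), and because it starts from the limit of > 2900 nM in this assay, at which 1 of the 2 values shown sits, its true size stays open.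

Compound 3 `N=C(N)c1ccc(O)c(CN2CC[C@H](NS(=O)(=O)c3cc4ccnc(Cl)c4s3)C2=O)c1` keeps the hydroxy group and alters only the group attached to the sulfonyl sulfur: a group of 10 heavy atoms (7 carbon, 1 nitrogen, 1 sulfur, 1 chlorine; one five-membered aromatic ring with 1 hetero atom, one six-membered aromatic ring with 1 hetero atom) in place of a group of 10 heavy atoms (7 carbon, 1 nitrogen, 1 sulfur, 1 chlorine; one five-membered aromatic ring with 1 hetero atom, one six-membered aromatic ring with 1 hetero atom), on a sulfonyl sulfur. Within the data shown here, no measured step touches this part of the molecule; the single known step concerns the hydroxy group instead, so it offers no guidance here. The expected step of no change at the digits printed from compound 2 to compound 3 (within the scatter) is therefore none beyond the scatter. Compound 3 is estimated to give 1600 nM in this assay, with a range from 500 nM to 5000 nM.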

Compound 3, inhibition constant: > 2900 nM
Compound 3 was reported as a limit; the forecaster's own chance of this, stated with the estimate: 30%; middle value at least 1.8-fold (0.25 log units) away from the limit.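

Compound 3 is the first compound shown to change the group on the sulfonyl sulfur, and it does so without changing a single atom, since only the way those atoms are joined differs from compound 2. In this assay compound 3 gives > 2900 nM, which is a limit of the assay and not a number. The comparison reads as an at least 1.8-fold higher number from compound 2 to compound 3 (0.25 log units; that floor lies within the scatter), which shows that this rearrangement does not produce a lower number, while the true size of the step stays open because the new value sits at a limit: the limit of > 2900 nM in this assay, at which 2 of the 3 values shown sit.

The two arrangements differ in how the ring nitrogen and the chlorine are joined within the group, so these compounds cannot separate the part played by the nitrogen from that played by the chlorine. From the compounds shown here alone, it also remains open whether another atom or group in place of the chlorine, such as a fluorine, a methyl group or an amine, would give a real number in this assay with either arrangement.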